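The source may report more compounds than this note shows. Statements on the series, on what has been measured and on what is new or still open speak of the compounds shown alone.

Working notes on the series in an assay for inhibition of Thromboxane-A synthase (Homo sapiens), using microsomes; a higher number here means a weaker inhibitor, a lower number a stronger inhibitor.

Three compounds with the same core are measured. Compound 1 `O=C(O)CC/C=C\CC1COC(c2ccccc2Cl)OC1c1cccnc1` gives 48 nM in this assay. Compound 2 `N#Cc1ccccc1C1OCC(C/C=C\CCC(=O)O)C(c2cccnc2)O1` gives 54 nM. Compound 3 `O=C(O)CC/C=C\CC1COC(c2ccc([N+](=O)[O-])cc2)OC1c1cccnc1` gives 39 nM, the lowest number of the three; its nearest neighbour is compound 1 and its furthest is compound 2, yet both gaps are within the scatter, so no order among the three can be read from these numbers.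

The steps between them: a 1.1-fold higher number from compound 1 to compound 2 (0.05 log units; within the scatter), a 1.2-fold lower number from compound 1 to compound 3 (0.09 log units; within the scatter) and a 1.4-fold lower number from compound 2 to compound 3 (0.14 log units; within the scatter). Every change of the aryl group on the saturated ring carbon has so far left the number where it was.

Compound 4 `O=C(O)CC/C=C\CC1COC(c2cccs2)OC1c1cccnc1` is not yet measured. Its difference from compound 3: thiophen-2-yl in place of 4-nitrophenyl on a saturated ring carbon. Among the compounds with values here, the steps that bear on it are those that also swap the group on this saturated ring carbon, from compound 1 to compound 3 and from compound 2 to compound 3, and both were within the scatter. On that basis, no step beyond the scatter is expected for compound 4 in this assay; the expected step is a 1.2-fold higher number from compound 3 to compound 4 (0.06 log units; within the scatter). The estimate for compound 4 is 45 nM, with a range from 20 nM to 100 nM.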

Compound 4, half-maximal inhibitory concentration: 71 nM
Compound 4: the middle estimate sits 1.6-fold (0.20 log units) below what was measured, and the stated range covers the measured number.
By their numbers in this assay, from the lowest: compounds 3, 1, 2 and 4 (each within the scatter of the next).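

In this assay, the saturated ring carbon between two ring oxygen atoms also accepts thiophen-2-yl, a five-membered aromatic ring with 1 hetero atom, without a step beyond the scatter: a 1.8-fold higher number from compound 3 to compound 4 (0.26 log units; within the scatter) and a 1.3-fold higher number from compound 2 to compound 4 (0.12 log units; within the scatter) and a 1.5-fold higher number from compound 1 to compound 4 (0.17 log units; within the scatter) are all printed as within it. The earlier compounds shown here varied only the substituted phenyl group, so the insensitivity of this position now extends, across these four compounds, to a change of aromatic ring type and to a group with fewer heavy atoms than 4-nitrophenyl. No measurement is available that would explain these numbers.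

On these data alone, a group without an aromatic ring at this carbon, such as cyclohexyl or methyl, and a phenyl group bearing an amine or a carboxylic acid remain open, so the limits of this insensitivity are unknown. All four compounds keep the pyridin-3-yl and 5-carboxypent-2-en-1-yl groups, which leaves open how a replacement of the pyridine by a phenyl group, or a shorter or longer acid chain, would read in this assay.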